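A few compounds are considered here, and "the series" means these few. Any claim that something is new, unique, unknown or untested is made for them only; others in the source may bear on it.

Measured compounds:
compound 1, `N#Cc1cc(=O)[nH]c(=O)n1[C@@H]1O[C@H](CO)[C@@H](O)[C@H]1O`: > 50000 nM
compound 2, `[N-]=[N+]=Nc1cc(=O)[nH]c(=O)n1[C@@H]1O[C@H](CO)[C@@H](O)[C@H]1O`: > 50000 nM

In a functional assay on OCI-Ly7 cells (Homo sapiens) for antiproliferative activity, read by WST assay, with a stated time of 3 days (on this read-out lower numbers stand for stronger inhibition and higher numbers for weaker inhibition), compound 1 returns > 50000 nM, which is a limit of the assay and not a number. Compound 2 returns > 50000 nM, again only a limit. Compound 2 thus stands at the limit shared by both values shown, as the limit of > 50000 nM in this assay, at which 2 of the 2 values shown sit, records, and nothing in the numbers places it higher or lower than compound 1. Within the data shown here, the single measured step, a step that the two limits leave unreadable from compound 1 to compound 2, cannot be read. The two limits hide its size and direction.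

Compound 3 is `CN(C)c1cc(=O)[nH]c(=O)n1[C@@H]1O[C@H](CO)[C@@H](O)[C@H]1O`. It differs from compound 2 by dimethylamino in place of azido on an aromatic carbon. Among the measured compounds shown here, the one measured step concerns the same position on the shared core, yet it offers no size, so no step beyond the scatter can be expected in this assay in either direction; the step that the limit leaves unreadable from compound 2 to compound 3 is expected to be flat. Compound 3 is expected to remain at the limit, with an estimate of 80000 nM, ranging from 20000 nM to 300000 nM.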

Compound 3, half-maximal inhibitory concentration: > 50000 nM
Compound 3: a limit, no number; the forecaster's own chance of this, stated with the estimate: 85%; the middle value is on the limit's open side.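

In this assay compound 3 gives > 50000 nM, which is a limit of the assay and not a number, so the steps from compound 1 and from compound 2 to compound 3 cannot be read. The compounds shown leave open how compound 1, compound 2 and compound 3 would rank, and whether any group at this place on the shared core gives a measurable value in this assay.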